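This account rests on a few compounds, and the source may have more. Where it says the series, first, only, none or still open, it means among the compounds named here.

Measured compounds:
- compound 1 `O=S(=O)(NCCCCCCNCc1ccc(Br)cc1)c1ccccc1Cl`: 13700 nM
- compound 2 `O=S(=O)(NCCNCc1cccc2ccccc12)c1cc(C(F)(F)F)cc(C(F)(F)F)c1`: 26000 nM

Of the compounds shown here, two have been measured in a functional assay on MIA PaCa-2 cells (Homo sapiens) for inhibition, read by MTT assay, with a stated time of 72 h; on this read-out lower numbers stand for stronger inhibition of growth and higher numbers for weaker inhibition of growth. Compound 1 gives 13700 nM, the lower of the two numbers, and compound 2 gives 26000 nM; the gap between them lies within the scatter, so the two values cannot be told apart. The next compound, compound 3 `O=S(=O)(NCCCCCCNCc1ccc(Br)cc1)c1ccc2ccsc2c1`, keeps the whole chain and the bromobenzyl end of compound 1 and changes only the group on the sulfonyl sulfur: 1-benzothiophen-6-yl in place of 2-chlorophenyl on a sulfonyl sulfur. Within the data shown here, no measured pair shows what such an exchange on the sulfonyl sulfur does, so the expectation rests on the value of compound 1 alone. The step from compound 1 to compound 3 in this assay is expected to be small, a 1.2-fold lower number from compound 1 to compound 3 (0.10 log units; within the scatter), not beyond the scatter in either direction. Compound 3 is therefore estimated at 11000 nM, with a range from 3500 nM to 35000 nM.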

Compound 3, concentration for 50% growth inhibition: 6000 nM
For compound 3 the middle estimate is 1.8-fold (0.26 log units) above the measured one; the range from low to high includes it.
By their numbers in this assay, from the lowest: compound 3; then compounds 1 and 2 (each within the scatter of the next).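

In this assay, the group on the sulfonyl sulfur is shown for the first time to affect the read-out: with the chain and the bromobenzyl end held constant, replacing 2-chlorophenyl with 1-benzothiophen-6-yl gives a 2.3-fold lower number from compound 1 to compound 3 (0.36 log units; beyond the scatter) on a modest scale. The position therefore tolerates the loss of the chlorine and the arrival of a five-membered aromatic ring containing sulfur, with no loss of growth inhibition, although this rests on a single pair. Nothing available gives a reason for the step.

From the compounds shown here alone, it remains open whether the step comes from removing the chlorine or from adding the second ring. An unsubstituted phenyl or an indol-6-yl group on the sulfonyl sulfur would help separate these, and whether the same exchange holds with other chains is also unknown.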